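The compounds below may be only part of what the source reports. "The series", "measured", "known", "first", "only" and "open" are said of these compounds alone.

Compound 1 `COc1ccc(-c2ccc(-c3ccc(-c4nc5cc(C)ccc5[nH]4)cc3)cc2)cc1OC` gives 2100 nM in a functional assay on A549 cells (Homo sapiens) for inhibition, read by sulforhodamine B assay; a lower number here means a stronger inhibitor of growth, a higher number a weaker inhibitor of growth.
Compound 2 `Oc1cccc2[nH]c(-c3ccc(-c4ccc(-c5ccccc5)cc4)cc3)nc12` gives 8320 nM.
Compound 3 `COc1ccc(-c2ccc(-c3ccc(-c4nc5c(O)cccc5[nH]4)cc3)cc2)cc1OC` gives 1310 nM.

Compound 4 `Cc1ccc2[nH]c(-c3ccc(-c4ccc(-c5ccccc5)cc4)cc3)nc2c1` has not yet been measured in this assay. It keeps the core of compound 1, and how that core differs from the core of compound 3 is this: 5-methyl-1H-benzimidazol-2-yl in place of 4-hydroxy-1H-benzimidazol-2-yl on an aromatic carbon. That difference gave a 1.6-fold lower number from compound 1 to compound 3 (0.20 log units; within the scatter). The change from compound 1 to compound 4 is phenyl in place of 3,4-dimethoxyphenyl on an aromatic carbon. The same change has been made once before, between two measured compounds: phenyl in place of 3,4-dimethoxyphenyl on an aromatic carbon. There it gave a 6.4-fold higher number from compound 3 to compound 2 (0.80 log units; beyond the scatter), a clear weakening of growth inhibition. For the measured compounds named here, a step of similar size is expected from compound 1 to compound 4, a 5.7-fold higher number from compound 1 to compound 4 (0.76 log units; beyond the scatter), because the single earlier example gave a 6.4-fold higher number from compound 3 to compound 2 (0.80 log units; beyond the scatter); with only one example, the size is uncertain. Compound 4 is therefore expected to give about 12000 nM, most likely between 5000 nM and 30000 nM.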

Compound 4, concentration for 50% growth inhibition: 3630 nM
Estimate against measurement, compound 4: 3.3-fold (0.52 log units) above, outside the stated range (below it).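

Putting phenyl in place of 3,4-dimethoxyphenyl gave a 1.7-fold higher number from compound 1 to compound 4 (0.24 log units; within the scatter) in this assay, so on this core the change made no clear difference. The size of the step therefore does not carry over from one core to the other: the same change on two cores in this assay, a 6.4-fold higher number (0.80 log units; beyond the scatter) from compound 3 to compound 2 and a 1.7-fold higher number (0.24 log units; within the scatter) from compound 1 to compound 4, 3.7-fold (0.57 log units) apart, beyond the scatter of two such steps. These two pairs show that the effect of the change depends on the core, but not whether the 5-methyl-1H-benzimidazol-2-yl or the 4-hydroxy-1H-benzimidazol-2-yl group is responsible, nor how the change would behave on a third core.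

Going by these compounds, it remains open how a phenyl carrying a single methoxy group, or a phenyl carrying an amine, would behave in place of 3,4-dimethoxyphenyl on these cores.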